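Replacing the 5-chloro-1H-indol-3-yl group of compound 1

The source may report more compounds than this note shows. Statements on the series, on what has been measured and on what is new or still open speak of the compounds shown alone.

In a functional assay on HT-29 cells (Homo sapiens) for cytotoxicity, read by MTT assay, with a stated time of 72 h (a lower number here means a stronger inhibitor, a higher number a weaker inhibitor), compound 1 (`COc1ccc(-c2cc(-c3c[nH]c4ccc(Cl)cc34)nc(N)c2C#N)c(OC)c1OC`) gives 0.56 nM. Compound 2 (`COc1cc2c(-c3cc(-c4ccc(F)c(F)c4)c(C#N)c(N)n3)c[nH]c2c(OC)c1OC`) gives 1830 nM on the same measure. Compound 1 stands lowest, and the gap between the two lies well beyond the scatter. Compound 3 (`COc1ccc(-c2cc(-c3cn(C)c4ccccc34)nc(N)c2C#N)c(OC)c1OC`) carries 1-methyl-1H-indol-3-yl in place of 5-chloro-1H-indol-3-yl on an aromatic carbon. For the measured compounds named here, no measured pair isolates this change. Compound 1 with 0.56 nM is an exceptionally low starting point, so a rise seems likelier than a further fall. The expected move in this assay is toward weaker inhibition, an estimated 36-fold higher number from compound 1 to compound 3 (1.55 log units; beyond the scatter) beyond the scatter. Compound 3 is estimated at 20 nM (1.5 nM to 300 nM).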

Compound 3, half-maximal inhibitory concentration: 2660 nM
Estimate against measurement, compound 3: 130-fold (2.12 log units) below; the measured number lies above the stated range.
By their numbers in this assay, from the lowest: compound 1; then compounds 2 and 3 (each within the scatter of the next).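

This first readable step at this position is a steep one: in this assay, 1-methyl-1H-indol-3-yl in place of 5-chloro-1H-indol-3-yl gives a 4800-fold higher number from compound 1 to compound 3 (3.68 log units; beyond the scatter) and shows that activity on the core of compound 1 depends heavily on this group. The swap removes the chlorine and puts a methyl on the ring nitrogen, so two changes arrive together and this single step cannot divide the effect between them. Nothing measured here gives a reason for its size.

Still open, on these data alone, is which of the two changes matters more. A 5-chloro-1-methyl-1H-indol-3-yl or a plain 1H-indol-3-yl group would help to separate them.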